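A few compounds are considered here, and "the series" means these few. Any claim that something is new, unique, unknown or untested is made for them only; others in the source may bear on it.

Compound 1 `CCCCC1CCC(OC(=O)N[C@@H](CC(C)C)C(=O)N[C@H](C=O)C[C@@H]2CCNC2=O)CC1` is the reference point of this small set. Among the measured compounds shown here, in a toxicity assay on L929 cells (Mus musculus) for cytotoxicity (a lower number here means that less compound is tolerated, a higher number that more compound is tolerated), compound 1 gives 63300 nM, the only actual number among the three values shown. Compound 2 `CCCC1CCC(OC(=O)N[C@@H](CC(C)C)C(=O)N[C@H](C=O)C[C@@H]2CCNC2=O)CC1` sits at a limit of the assay rather than at a number: in this assay compound 2 gives > 100000 nM. Compound 3 `CC(C)C[C@H](NC(=O)OCC1CCC(F)(F)CC1)C(=O)N[C@H](C=O)C[C@@H]1CCNC1=O` likewise returns a limit, and in this assay compound 3 gives > 100000 nM. For the measured compounds named here, the two readable steps, an at least 1.5-fold higher number from compound 1 to compound 2 (0.19 log units; that floor lies within the scatter) and an at least 1.5-fold higher number from compound 1 to compound 3 (0.19 log units; that floor lies within the scatter), are floored by the limit of > 100000 nM in this assay, at which 2 of the 3 values shown sit, and say only that both changes leave the tolerated concentration no lower than that of compound 1. The remaining pair gives a step that the two limits leave unreadable from compound 2 to compound 3, both of its values being limits.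

Compound 4 `CCCCC1CCC(OC(=O)N[C@@H](CC(C)C)C(=O)N[C@@H](C[C@@H]2CCNC2=O)C(O)S(=O)(=O)O)CC1` is the unmeasured member. Its difference from compound 1 is hydroxy(sulfo)methyl in place of formyl on a saturated chain carbon bound to an amide-type nitrogen and a saturated chain carbon. Going by the values given here, none of the measured steps touches this position; the two known steps concern another part of the structure and their size is not readable. The expectation is therefore anchored on compound 1, with a modest drift in the direction the known steps show, so that a 1.3-fold higher number from compound 1 to compound 4 (0.10 log units; within the scatter) is expected. Compound 4 is estimated at 80000 nM, within 40000 nM to 160000 nM, with a real chance that only a limit is reported.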

Compound 4, half-maximal cytotoxic concentration: 59100 nM
For compound 4 the middle estimate is 1.4-fold (0.13 log units) above the measured one; the range from low to high includes it.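

Among the compounds shown here, compound 4 gives the first reading at this position, on a saturated chain carbon bound to an amide-type nitrogen and a saturated chain carbon, whereas the earlier steps changed another part of the structure. In this assay, hydroxy(sulfo)methyl in place of formyl gives a 1.1-fold lower number from compound 1 to compound 4 (0.03 log units; within the scatter), so the two compounds cannot be told apart even though the entering group has more heavy atoms, hydrogen-bond donors and hydrogen-bond acceptors than formyl. Unlike the earlier readable steps, which are only floors set by a limit, this step has an actual number at both ends.

From the compounds shown here alone, whether the read-out would also hold with a carboxylic acid or a nitrile at this position remains open, as does whether hydroxy(sulfo)methyl would leave it unchanged on the 4-propylcyclohexyl compound or the (4,4-difluorocyclohexyl)methyl compound. Those two compounds return only limits, the step between them cannot be read, and neither offers a number against which such a change could be sized: the limit of > 100000 nM in this assay, at which 2 of the 4 values shown sit.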